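The compounds below may be only part of what the source reports. "The series", "measured", "known", "first", "only" and "open" are said of these compounds alone.

Measured so far:
- compound 1, `COc1ccccc1-c1cc(O)c2cc(C)cnc2n1`: 19500 nM
- compound 2, `COc1cccc(-c2cc(O)c3c(C)cc(C)nc3n2)c1`: 251 nM

In a functional assay on OVCAR-3 cells (Homo sapiens) (on this read-out higher numbers stand for weaker inhibition of growth and lower numbers for stronger inhibition of growth), compound 1 gives 19500 nM, the highest of the two numbers measured. Compound 2 differs from compound 1 in several places at once; in this assay compound 2 gives 251 nM, a far lower number, and the gap between the two lies beyond the scatter. Among the compounds with values here, no single-change step between measured compounds is available, so nothing can be said about which of the several differences carries that gap.

The next compound, compound 3, `COc1ccccc1-c1cc(O)c2cccnc2n1`, is compound 1 with a single change: hydrogen in place of methyl on an aromatic carbon. Nothing measured here shows what the loss of a methyl at that place does on its own. Removing one carbon and no hydrogen-bond donor or acceptor is the kind of change that commonly moves a number only a little; no step beyond the scatter is expected in this assay, in either direction, and a drift to a slightly weaker value is about as likely as none.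

Compound 3 is therefore estimated at 25000 nM in this assay, with a range of 8000 nM to 80000 nM; the expected step is a 1.3-fold higher number from compound 1 to compound 3 (0.11 log units; within the scatter).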

Compound 3, concentration for 50% growth inhibition: 47900 nM
Estimate against measurement, compound 3: 1.9-fold (0.28 log units) below, and the stated range covers the measured number.
By their numbers in this assay, from the lowest: compound 2; then compound 1; then compound 3.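

In this assay, within the data shown here, the methyl on this aromatic carbon, two atoms from the ring nitrogen, proves not to be a silent substituent: hydrogen in its place gives a 2.5-fold higher number from compound 1 to compound 3 (0.39 log units; beyond the scatter), a modest step but the first single-change step that can be read. Small as the change is, this position registers it, and on this one pair the loss of the methyl goes with weaker inhibition of growth, while the size of the step remains close to the usual scatter of the read-out. Nothing available explains the step, so it stands as an observation on one pair of compounds.

Going by these compounds, whether a longer chain such as ethyl, or a methoxy group, a chlorine atom or an amine on the same aromatic carbon would lower the number further or raise it remains open. Also open, on these data alone, is whether the methyl has a similar effect when the rest of the molecule differs from the core of compound 1, since a single pair sets no trend.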